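Fluoro to Methoxy on the Benzyl Ring of Compound 3

This account rests on a few compounds, and the source may have more. Where it says the series, first, only, none or still open, it means among the compounds named here.

Compound 1 `O=c1ccoc2cc(OCc3cn(Cc4ccc(Cl)cc4Cl)nn3)ccc12` gives 13300 nM in a functional assay on QGY7701 cells (Homo sapiens) for cytotoxicity, read by MTT assay, with a stated time of 48 h; a higher number here means a weaker inhibitor, a lower number a stronger inhibitor.
Compound 2 `CC(C)(C)c1ccc(Cn2cc(COc3ccc4c(=O)ccoc4c3)nn2)cc1` gives > 100000 nM in this assay; this is a limit of the assay, not a number.
Compound 3 `O=c1ccoc2cc(OCc3cn(Cc4ccc(F)cc4)nn3)ccc12` gives 14400 nM in this assay.

Among the numbers shown, compound 3 holds the higher of the two; its nearest neighbour is compound 1, and the step of a 1.1-fold higher number from compound 1 to compound 3 (0.03 log units; within the scatter) lies within the scatter, so the two cannot be told apart. Compound 2 sits at the limit of > 100000 nM in this assay, at which 1 of the 3 values shown sits. Within the data shown here, the only step that touches the same aromatic carbon is an at least 6.9-fold lower number from compound 2 to compound 3 (0.84 log units; beyond the scatter), where a bulky tert-butyl group gave way to fluoro and the number fell clearly.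

The next compound, compound 4 `COc1ccc(Cn2cc(COc3ccc4c(=O)ccoc4c3)nn2)cc1`, differs from compound 3 in one place: methoxy in place of fluoro on an aromatic carbon. Methoxy is larger than fluoro but far smaller than tert-butyl, so the one relevant step, an at least 6.9-fold lower number from compound 2 to compound 3 (0.84 log units; beyond the scatter), sets only a loose upper bound on how much the number might rise. No measured step gives a reason to expect a fall. The expectation is therefore a small rise or none beyond the scatter. In this assay compound 4 is estimated at 20000 nM, with a range from 8000 nM to 60000 nM, which amounts to an expected 1.4-fold higher number from compound 3 to compound 4 (0.14 log units; within the scatter).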

Compound 4, half-maximal inhibitory concentration: 56600 nM
Beside the measured number, compound 4's estimate is 2.8-fold (0.45 log units) below it, and the stated range covers the measured number.
By their numbers in this assay, from the lowest: compounds 1 and 3 (each within the scatter of the next); then compound 4. At a limit, above all of these: compound 2.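

Methoxy in place of fluoro on this aromatic carbon, para to a large group, gives a 3.9-fold higher number from compound 3 to compound 4 (0.59 log units; beyond the scatter). Among these compounds, this is the first step at this carbon with a true number at both ends, and it shows that a change of one heavy atom leaving and two entering can move the number beyond the scatter. The step that also changes the ring's substitution, a 4.3-fold higher number from compound 1 to compound 4 (0.63 log units; beyond the scatter), points the same way, so compound 4 stands above both compound 1 and compound 3, which themselves cannot be told apart. Compound 2 stands at a limit of the assay: the limit of > 100000 nM in this assay, at which 1 of the 4 values shown sits. The step that starts from this limit is an at least 1.7-fold lower number from compound 2 to compound 4 (0.24 log units; that floor lies within the scatter), and as its floor lies within the scatter, it shows no clear gap.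

The compounds shown give no cause for the rise, and they cannot say whether it follows from the oxygen, the added carbon or the two together. A methyl or a hydroxyl group on the same carbon would help separate these, as each carries only one of the two atoms that methoxy brings.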